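Trifluoromethoxy step carried onto a second core

A few compounds are considered here, and "the series" means these few. Any claim that something is new, unique, unknown or untested is made for them only; others in the source may bear on it.

Compound 1 `COc1cccc(-c2nc3ccc(C)cc3c(=O)[nH]2)c1` and compound 3 `COc1cccc(-c2nc3cc(C)ccc3c(=O)[nH]2)c1` are built from the same atoms joined differently; the difference between the two cores is not broken down here. In an assay on isolated protein for inhibition of DNA topoisomerase 1 (Homo sapiens), with a stated time of 30 min, tested at 100 uM (on this read-out lower numbers stand for a weaker effect and higher numbers for a stronger effect at the one concentration tested), compound 1 gives 71.8% and compound 3 gives 100%. Compound 2 `Cc1ccc2nc(-c3cccc(OC(F)(F)F)c3)[nH]c(=O)c2c1` carries trifluoromethyl in place of methyl on an oxygen on an aromatic ring relative to compound 1; in this assay compound 2 gives 98.6%, a step of a number 26.8 percentage points higher from compound 1 to compound 2 (beyond the scatter). Compound 4 `Cc1ccc2c(=O)[nH]c(-c3cccc(OC(F)(F)F)c3)nc2c1` places the same change, (trifluoromethyl in place of methyl on an oxygen on an aromatic ring), onto the core of compound 3 and awaits measurement in this assay. Because compound 3 already gives 100%, no room is left for a rise of the earlier size, and the step is expected to be only a number 1 percentage points lower from compound 3 to compound 4 (within the scatter). Compound 4 is therefore expected to give about 99%, between 93% and 100%.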

Compound 4, a percentage reported as inhibition, at one concentration (the size of the read-out at that concentration, not a potency): 77.2%
Beside the measured number, compound 4's estimate is 21.8 percentage points above it, and the stated range ends above it.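

In this assay, the change from methoxy to trifluoromethoxy does not carry over unchanged from one core to the other; on the core of compound 3 it reads as a number 22.8 percentage points lower from compound 3 to compound 4 (beyond the scatter), and the two steps run in opposite directions and differ: the same change on two cores in this assay, a number 26.8 percentage points higher (beyond the scatter) from compound 1 to compound 2 and a number 22.8 percentage points lower (beyond the scatter) from compound 3 to compound 4, 49.6 percentage points apart, beyond the scatter of two such steps

For these two cores, the outcome of this change therefore depends on the core that carries it. This rests on one pair per core, each read at a single concentration, so it gives neither a potency nor a reason for the reversal, and it cannot be extended to other cores.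

Open, from the compounds shown here alone, is whether ethyl or a longer chain on the oxygen would also split between the two cores. Equally open, going by these compounds, is how an amine or a carboxylic acid in that place would behave on each core.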